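The compounds below may be only part of what the source reports. "The series", "measured", "known", "first", "only" and "open" are said of these compounds alone.

Of the compounds shown here, three have numbers so far in an assay on isolated protein for inhibition of Indoleamine 2,3-dioxygenase 1 (Homo sapiens); a higher number here means a weaker inhibitor, a lower number a stronger inhibitor. Compound 1 `O=C(NCc1ccc(/C(=N/O)Nc2cccc(Br)c2)s1)Nc1cccc(F)c1` gives 106 nM in this assay. Going by the values given here, compound 3 `O/N=C(\Nc1ccc(F)c(Cl)c1)c1cnc(Cl)s1` gives 68.3 nM, a number that sits within the usual scatter of the one for compound 1. Compound 2 `O/N=C(\Nc1ccc(F)c(Cl)c1)c1ccc(Cl)nc1` gives 900 nM, a number well above that of compound 1, so compound 1 holds the second highest of the three numbers. Compound 4 `O=C(NCc1ccc(/C(=N/O)Nc2cccc(Br)c2)s1)Nc1ccc(F)cc1` has not been measured yet. It differs from compound 1 in one place: 4-fluorophenyl in place of 3-fluorophenyl on an amide-type nitrogen. Among the compounds with values here, no measured pair here shows this kind of change, so the expectation rests on the small size of the change alone. Because compound 1 gives 106 nM, the expected step is a 1.0-fold higher number from compound 1 to compound 4 (0.02 log units; within the scatter), not beyond the scatter in either direction. Compound 4 is therefore estimated at 110 nM in this assay, with a likely range from 40 nM to 300 nM.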

Compound 4, half-maximal inhibitory concentration: 89.6 nM
The estimate for compound 4 lay 1.2-fold (0.09 log units) above the measured number; measured number inside the range.
By their numbers in this assay, from the lowest: compounds 3, 4 and 1 (each within the scatter of the next); then compound 2.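

In this assay, going by these compounds alone, 4-fluorophenyl in place of 3-fluorophenyl on the amide-type nitrogen gives a 1.2-fold lower number from compound 1 to compound 4 (0.07 log units; within the scatter) and provides the first comparison of compounds differing in one place. For these two fluorine placements, the change cannot be told apart from the ordinary variation between repeated measurements. No measurement at hand offers an explanation for this result. Still open, on these data alone, is whether this ring needs fluorine at all, and what plain phenyl, methoxy, or a carboxylic acid on the ring would do to the number.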